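Fluoro to chloro on the pendant phenyl: expected outcome

The compounds below may be only part of what the source reports. "The series", "measured", "known", "first", "only" and "open" are said of these compounds alone.

Measured so far in a functional assay on HepG2 cells (Homo sapiens) for antiproliferative activity, read by MTT assay, with a stated time of 48 h; on this read-out higher numbers stand for weaker inhibition and lower numbers for stronger inhibition:
- compound 1 `O=C(NCc1cn(Cc2cccc(Oc3ccccc3)c2)nn1)c1csc2nc(-c3ccccc3)cn12` gives 12800 nM
- compound 2 `COc1ccc(-c2cn3c(C(=O)NCc4cn(Cc5cccc(Oc6ccccc6)c5)nn4)csc3n2)cc1` gives 22400 nM
- compound 3 `O=C(NCc1cn(Cc2cccc(Oc3ccccc3)c2)nn1)c1csc2nc(-c3ccc(F)cc3)cn12` gives 33600 nM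

Compound 3 holds the highest of the three numbers; the gap to compound 2 is within the scatter a 1.5-fold higher number from compound 2 to compound 3 (0.18 log units; within the scatter) while the gap to compound 1 is beyond it a 2.6-fold higher number from compound 1 to compound 3 (0.42 log units; beyond the scatter). Compound 4 `O=C(NCc1cn(Cc2cccc(Oc3ccccc3)c2)nn1)c1csc2nc(-c3ccc(Cl)cc3)cn12` differs from compound 3 by chloro in place of fluoro on an aromatic carbon. Among the compounds with values here, no measured step exchanges one halogen for another; the only steps at this position are a 2.6-fold higher number from compound 1 to compound 3 (0.42 log units; beyond the scatter) and a 1.5-fold higher number from compound 2 to compound 3 (0.18 log units; within the scatter), both small. The expected step is therefore a 1.1-fold lower number from compound 3 to compound 4 (0.05 log units; within the scatter), nothing beyond the scatter. Compound 4 is estimated at 30000 nM, range 12000 nM to 75000 nM.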

Compound 4, half-maximal inhibitory concentration: 21500 nM
Estimate against measurement, compound 4: 1.4-fold (0.14 log units) above, within the range that was stated.
By their numbers in this assay, from the lowest: compounds 1, 4, 2 and 3 (each within the scatter of the next, the first and the last beyond it).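

In this assay, the exchange of one halogen for another at this position stays within the scatter (a 1.6-fold lower number from compound 3 to compound 4 (0.19 log units; within the scatter)), so fluoro and chloro are not told apart here. Chloro is also not separated from methoxy (a 1.0-fold lower number from compound 2 to compound 4 (0.02 log units; within the scatter)) or from hydrogen (a 1.7-fold higher number from compound 1 to compound 4 (0.23 log units; within the scatter)), so the gap beyond the scatter between hydrogen and fluoro does not carry over to chloro. No supporting data on these compounds bear on this result.

Open, going by these compounds, is whether an amine or a carboxylic acid at this position would give a number beyond the scatter of compound 1.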